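Replacing phenyl with cyclohexyl on the amide nitrogen

The source may hold more compounds than are shown below. What is called first, only, known or untested is meant among the compounds shown, and "the series" means these compounds.

Compound 1 is `C=CC1=C(C(=O)O)C(c2ccc(OC)cc2)OC1`. In a functional assay on QGY7701 cells (Homo sapiens) for cytotoxicity, read by MTT assay, with a stated time of 24 h (a higher number here means a weaker inhibitor, a lower number a stronger inhibitor), compound 1 gives only a limit, > 100000 nM, rather than a number. Compound 2 is `C=CC1=C(C(=O)Nc2ccccc2)C(c2ccc(OC)cc2)OC1`, the anilino analogue in place of hydroxy on the carbonyl carbon. In this assay compound 2 likewise reaches only the limit of > 100000 nM. The step that the two limits leave unreadable from compound 1 to compound 2 therefore has no readable size, since the limit of > 100000 nM in this assay, at which 2 of the 2 values shown sit, describes both values shown. Among the compounds with values here, compound 2 thus stands at the limit of the assay, with no number of its own; nothing among the measured compounds places it anywhere else.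

Compound 3 is `C=CC1=C(C(=O)NC2CCCCC2)C(c2ccc(OC)cc2)OC1`. It differs from compound 2 by cyclohexyl in place of phenyl on an amide-type nitrogen. Within the data shown here, no measured step bears on this change, and the only step available, from hydroxy to anilino, is itself unreadable. There is therefore no basis for expecting a step beyond the scatter in this assay, and compound 3 is expected to sit where compound 2 sits, a step that the limit leaves unreadable from compound 2 to compound 3. Compound 3 is accordingly estimated at 150000 nM, within a range from 40000 nM to 600000 nM, most likely reported again only as a limit.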

Compound 3, half-maximal inhibitory concentration: > 100000 nM
Compound 3 gave a limit, no number; the forecaster's own chance of this, stated with the estimate: 80%; the middle value is on the limit's open side.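

No size can be read for any step among compound 1, compound 2 and compound 3, since each gives only a limit rather than a number in this assay: the limit of > 100000 nM in this assay, at which 3 of the 3 values shown sit.

The compounds shown leave open how strongly any of the three acts on these cells, and whether exchanging phenyl for cyclohexyl on the amide nitrogen changes that at all.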